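Acyl heteroaryl ketones as fatty-acid amide hydrolase inhibitors

The source may report more compounds than this note shows. Statements on the series, on what has been measured and on what is new or still open speak of the compounds shown alone.

Measured so far:
- compound 1, `CCCCCCCC/C=C\CCCCCCC(=O)c1ncc(-c2ccoc2)o1`: 610 nM
- compound 2, `CCCCCCCC/C=C\CCCCCCC(=O)c1ccccn1`: > 100000 nM, a limit
- compound 3, `CCCCCCCC/C=C\CCCCCCC(=O)c1nc(-c2ccccc2)c(-c2ccccc2)o1`: > 100000 nM, a limit

All three share the long unsaturated acyl chain and differ only in the aromatic group on the carbonyl carbon. In an assay on isolated protein for inhibition of Fatty-acid amide hydrolase 1 (Homo sapiens) (a lower number here means a stronger inhibitor, a higher number a weaker inhibitor), compound 1 gives 610 nM. Compound 2 is reported only as the limit > 100000 nM, so no number is known for it. Compound 3 likewise sits at a limit, > 100000 nM. Compound 2 therefore stands at the limit of > 100000 nM in this assay, at which 2 of the 3 values shown sit, and its distance to compound 1 cannot be put as a number.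

Compound 4, `CCCCCCCC/C=C\CCCCCCC(=O)c1nc2cccnc2o1`, has not been measured. It differs from compound 2 as follows: a group of 9 heavy atoms (6 carbon, 2 nitrogen, 1 oxygen; one five-membered aromatic ring with 2 hetero atoms, one six-membered aromatic ring with 1 hetero atom) in place of a group of 6 heavy atoms (5 carbon, 1 nitrogen; one six-membered aromatic ring with 1 hetero atom), on a carbonyl carbon. The entering group carries a five-membered aromatic ring with two hetero atoms fused to the six-membered ring with one hetero atom, so it shares the oxazole-type ring of compound 1 while keeping the pyridine of compound 2.

For the measured compounds named here, no measured step connects these compounds, so the size of the move is open. The expectation in this assay is a step toward stronger inhibition, leaving the limit, estimated as an at least 33-fold lower number from compound 2 to compound 4 (1.52 log units; beyond the scatter) for compound 4. Compound 4 is expected to reach about 3000 nM, with a range from 300 nM to 50000 nM.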

Compound 4, inhibition constant: 11 nM
Beside the measured number, compound 4's estimate is 270-fold (2.44 log units) above it, and the stated range ends above it.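

In this assay, exchanging pyridin-2-yl for the group with one five-membered aromatic ring with 2 hetero atoms and one six-membered aromatic ring with 1 hetero atom, on the carbonyl carbon, gives an at least 9000-fold lower number from compound 2 to compound 4 (3.95 log units; beyond the scatter). Compound 2 remains a limit, so this step is a bound and not an exact size: the limit of > 100000 nM in this assay, at which 2 of the 4 values shown sit. Compound 1 gives 610 nM and compound 4 gives 11 nM, and both carry a five-membered aromatic ring with 2 hetero atoms on the carbonyl carbon, but compound 3 goes against any general link between that ring and a readable value, since it also carries such a ring.

A benzoxazol-2-yl group on the same carbonyl carbon would show whether the hetero atom of the six-membered ring matters for the value of compound 4. On these data alone, the share of the acyl chain also stays open, since all four compounds carry the same unsaturated chain, and a saturated chain would bear on this question.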